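Swapping a Ring-Bearing Group for Hydroxy: Will Cytotoxicity Move?

This account rests on a few compounds, and the source may have more. Where it says the series, first, only, none or still open, it means among the compounds named here.

In a functional assay on MT4 cells (Homo sapiens) for cytotoxicity, read by MTT assay, with a stated time of 72 h (a higher number here means a weaker inhibitor, a lower number a stronger inhibitor), compound 3 `Cc1c(C)c2c(c(C)c1OC(=O)CCC(=O)NC1CC(C)(C)N([O])C1(C)C)CCC(C)(C(=O)NC1CC(C)(C)N([O])C1(C)C)O2` gives 207000 nM. That number lies within the usual scatter of repeated measurements from both neighbouring results: compound 1 `Cc1c(C)c2c(c(C)c1OC(=O)CCC(=O)O)CCC(C)(C(=O)NC1CC(C)(C)N([O])C(C)(C)C1)O2` gives 165000 nM and compound 2 `Cc1c(C)c2c(c(C)c1OC(=O)CCC(=O)O)CCC(C)(C(=O)O)O2` gives 285000 nM. So these three compounds cannot be told apart in this assay.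

Compound 4 `Cc1c(C)c2c(c(C)c1OC(=O)CCC(=O)O)CCC(C)(C(=O)NC1CC(C)(C)N([O])C1(C)C)O2` differs from compound 3 by one oxygen atom in place of a group of 11 heavy atoms (8 carbon, 2 nitrogen, 1 oxygen; one five-membered non-aromatic ring with 1 hetero atom), on a carbonyl carbon. What enters is a hydroxy, and the carbonyl carbon's other neighbour is a saturated chain carbon.

The closest measured comparison is a 1.7-fold higher number from compound 1 to compound 2 (0.24 log units; within the scatter). Within the data shown here, there too, one oxygen atom replaces a large ring-bearing group on a carbonyl carbon, although that group holds a six-membered ring, and no measured step covers this exact swap. As that step stays within the scatter, no change beyond the scatter is expected in this assay. The estimated size of the change is a 1.1-fold lower number from compound 3 to compound 4 (0.03 log units; within the scatter). For compound 4, the expected value is 195000 nM, with an estimated range from 115000 nM to 320000 nM.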

Compound 4, half-maximal inhibitory concentration: > 300000 nM
Compound 4: a limit, no number; the forecaster's own chance of this, stated with the estimate: 5%; middle value at least 1.5-fold (0.18 log units) away from the limit.
By their numbers in this assay, from the lowest: compounds 1, 3 and 2 (each within the scatter of the next). At a limit, above all of these: compound 4.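

In this assay, compound 4 gives a limit of the assay and not a number: the limit of > 300000 nM in this assay, at which 1 of the 4 values shown sits. The steps to it can be read only as floors: an at least 1.4-fold higher number from compound 3 to compound 4 (0.16 log units; that floor lies within the scatter), an at least 1.0-fold higher number from compound 2 to compound 4 (0.02 log units; that floor lies within the scatter) and an at least 1.8-fold higher number from compound 1 to compound 4 (0.25 log units; that floor lies within the scatter). As far as these compounds go, they show that hydroxy on this carbonyl carbon, in place of the group holding the five-membered ring, brings no lower number, and that the five-membered ring group in place of the six-membered one on the amide-type nitrogen brings none either, while the true size of each change stays unknown.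

From the compounds shown here alone, whether any of these changes truly reaches beyond the scatter remains open. So does whether an amine or a longer chain on this carbonyl carbon would give a number that can be read in this assay.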